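Methoxy for Cyano on a Fused Core: Clearance Expectation

The compounds below may be only part of what the source reports. "The series", "measured", "known", "first", "only" and "open" are said of these compounds alone.

Compound 1: `COc1ccn2c(Nc3ccccc3F)c(-c3ccccn3)nc2c1` gives 133 uL/min in an ADME assay on microsomes from liver (Mus musculus) for metabolic stability, read by LC-MS, using NADPH, with a stated time of 60 min, tested at 1 uM, in the presence of a further agent that is not named here; on this read-out higher numbers stand for fast clearance and lower numbers for slow clearance.
Compound 2: `N#Cc1ccn2c(Nc3ccc(F)cc3)c(-c3ccccn3)nc2c1` gives 146 uL/min in this assay.

Compound 2 shows the highest of the two numbers in this assay, though compound 1 comes within the scatter of it, so the two read as alike. For the measured compounds named here, compound 1 and compound 2 differ in more than one place, and no single step between them is available.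

Compound 3, `COc1ccn2c(Nc3ccc(F)cc3)c(-c3ccccn3)nc2c1`, has not been run in this assay. Its change from compound 2 is methoxy in place of cyano on an aromatic carbon.

Because compound 1, which already carries a methoxy on its core, gives 133 uL/min, the methoxy is not expected to shift the number beyond the scatter. Compound 3 is therefore expected to give 135 uL/min, with a range of 75 uL/min to 250 uL/min. The estimated step of a 1.1-fold lower number from compound 2 to compound 3 (0.03 log units; within the scatter) is expected to be essentially none beyond the scatter.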

Compound 3, intrinsic clearance in a liver preparation (reported as CLH), per the amount of preparation that the assay uses: 117 uL/min
Compound 3: middle estimate off by 1.2-fold (0.06 log units), on the high side; low and high end bracket the measured number.
By their numbers in this assay, from the lowest: compounds 3, 1 and 2 (each within the scatter of the next).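

In this assay, methoxy in place of cyano on this aromatic carbon, opposite the ring nitrogen, gives a 1.2-fold lower number from compound 2 to compound 3 (0.10 log units; within the scatter), so the two groups read as alike at this position. A second single change, 4-fluorophenyl in place of 2-fluorophenyl on the nitrogen, gives a 1.1-fold lower number from compound 1 to compound 3 (0.06 log units; within the scatter), so this exchange on the aromatic amine also stays within the scatter. Nothing measured here accounts for these results.

The compounds shown leave open whether another group on the same aromatic carbon, such as an amine or a carboxylic acid, would separate from methoxy and cyano in this read-out. They also leave open how an unsubstituted phenyl on the nitrogen would compare with the two fluorophenyl groups.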